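A triazole ester series sitting at the assay ceiling

The source may report more compounds than this note shows. Statements on the series, on what has been measured and on what is new or still open speak of the compounds shown alone.

Compound 1 `C/C(=C\CC/C(C)=C/CC[C@@H]1[C@@]2(C)CCC(=O)C(C)(C)[C@H]2CC[C@@]1(C)O)CC/C=C(\C)C(=O)OCc1cn(-c2ccc(F)cc2)nn1` in a functional assay on A549 cells (Homo sapiens) for antiproliferative activity, read by MTT assay, with a stated time of 48 h (on this read-out higher numbers stand for weaker inhibition and lower numbers for stronger inhibition), gives > 150000 nM, a limit.
Compound 2 `C/C(=C\CC/C(C)=C/CC[C@@H]1[C@@]2(C)CCC(=O)C(C)(C)[C@H]2CC[C@@]1(C)O)CC/C=C(\C)C(=O)OCc1cn(-c2ccccc2Br)nn1` gives > 150000 nM, a limit.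
Compound 3 `C/C(=C\CC/C(C)=C/CC[C@@H]1[C@@]2(C)CCC(=O)C(C)(C)[C@H]2CC[C@@]1(C)O)CC/C=C(\C)C(=O)OCc1cn(-c2ccc(Br)cc2)nn1` gives > 150000 nM, a limit.

Compound 3 stands at the limit of the assay, the same limit at which every value shown sits (the limit of > 150000 nM in this assay, at which 3 of the 3 values shown sit). Compound 4 `C/C(=C\CC/C(C)=C/CC[C@@H]1[C@@]2(C)CCC(=O)C(C)(C)[C@H]2CC[C@@]1(C)O)CC/C=C(\C)C(=O)OCc1cn(-c2cccc(O)c2)nn1` differs from it by 3-hydroxyphenyl in place of 4-bromophenyl on an aromatic nitrogen. Three measured steps also alter the aryl group on the ring nitrogen: a step that the two limits leave unreadable from compound 1 to compound 2, a step that the two limits leave unreadable from compound 2 to compound 3 and a step that the two limits leave unreadable from compound 1 to compound 3, and none of them is readable in size, since both ends are limits. Among the compounds with values here, no measured step can therefore set a size or direction for the change to compound 4. The expected step that the limit leaves unreadable from compound 3 to compound 4 is taken as none beyond the scatter. Compound 4 is estimated at 200000 nM, with a range from 100000 nM to 400000 nM, and the assay is expected most likely to report only a limit again.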

Compound 4, half-maximal inhibitory concentration: 42800 nM
Beside the measured number, compound 4's estimate is 4.7-fold (0.67 log units) above it; the measured number lies below the stated range.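

Replacing the aryl group on the aromatic nitrogen with 3-hydroxyphenyl gives an at least 3.5-fold lower number from compound 3 to compound 4 (0.54 log units; beyond the scatter) and an at least 3.5-fold lower number from compound 2 to compound 4 (0.54 log units; beyond the scatter) and also an at least 3.5-fold lower number from compound 1 to compound 4 (0.54 log units; beyond the scatter) in the same series. Within the data shown here, these are the first readable steps at this position, since the steps among the halogen-bearing aryl groups cannot be read. In this assay only compound 4 has left the ceiling: the limit of > 150000 nM in this assay, at which 3 of the 4 values shown sit.

As far as these compounds go, whether this depends on the hydroxyl group itself or on where it sits stays open. A 4-hydroxyphenyl, 3-methoxyphenyl or 3-aminophenyl group would bear on that question.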